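The source may report more compounds than this note shows. Statements on the series, on what has been measured and on what is new or still open speak of the compounds shown alone.

Compound 3 `CC(C)=CCC1=C(OCc2cn(-c3ccccc3)nn2)C(=O)c2ccccc2C1=O` holds the lowest of the three numbers in an ADME assay on HepG2 cells (Homo sapiens) for cytotoxicity, read by MTT assay, with a stated time of 24 h; a higher number here means that more compound is tolerated, a lower number that less compound is tolerated: compound 3 gives 100000 nM, whereas compound 1 `CC(C)=CCC1=C(OCc2cn(C3CCNCC3)nn2)C(=O)c2ccccc2C1=O` gives 570000 nM and compound 2 `CC(C)=CCC1=C(OCc2cn(Cc3ccccn3)nn2)C(=O)c2ccccc2C1=O` gives 658000 nM. Both steps onto compound 3 were modest and beyond the scatter, a 5.7-fold lower number from compound 1 to compound 3 (0.76 log units; beyond the scatter) and a 6.6-fold lower number from compound 2 to compound 3 (0.82 log units; beyond the scatter), while the step between the other two stayed within it, a 1.2-fold higher number from compound 1 to compound 2 (0.06 log units; within the scatter). Compound 4 `COc1ccc(-n2cc(COC3=C(CC=C(C)C)C(=O)c4ccccc4C3=O)nn2)c([N+](=O)[O-])c1` carries 4-methoxy-2-nitrophenyl in place of phenyl on an aromatic nitrogen. The group on this aromatic nitrogen is the only place varied so far, and every measured change there shifted this assay only modestly. Among the compounds with values here, no measured step adds substituents to that phenyl ring, so the direction stays open. Compound 4 is therefore expected near 80000 nM, in a range of 30000 nM to 250000 nM, a step of a 1.3-fold lower number from compound 3 to compound 4 (0.10 log units; within the scatter) that may not exceed the scatter.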

Compound 4, half-maximal cytotoxic concentration: 532000 nM
Compound 4: the middle estimate sits 6.7-fold (0.82 log units) below what was measured; the measured number lies above the stated range.
By their numbers in this assay, from the lowest: compound 3; then compounds 4, 1 and 2 (each within the scatter of the next).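

On the aromatic nitrogen, a substituted phenyl ring behaves quite differently from plain phenyl in this assay, with a 5.3-fold higher number from compound 3 to compound 4 (0.73 log units; beyond the scatter) as the step. The 4-methoxy-2-nitrophenyl group stands level with the other two groups, through a 1.2-fold lower number from compound 2 to compound 4 (0.09 log units; within the scatter) and a 1.1-fold lower number from compound 1 to compound 4 (0.03 log units; within the scatter) as its steps, which leaves compound 3 alone apart from the other three. Nothing available explains this step.

As far as these compounds go, whether the methoxy or the nitro group carries the step stays open, since the two enter together. From the compounds shown here alone, how an amine or a carboxylic acid on that phenyl ring would read in this assay also stays open.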